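The compounds below may be only part of what the source reports. "The series", "measured", "known", "first", "only" and "open" are said of these compounds alone.

Measured compounds in an ADME assay on HEK293 cells (Homo sapiens) for antiproliferative activity, read by MTT assay, with a stated time of 24 h; on this read-out higher numbers stand for weaker inhibition and lower numbers for stronger inhibition:
Compound 1, `COc1ccc(-c2cc(/C=C/C(=O)c3cc(OC)c(OC)c(OC)c3)nc3cc(-c4ccccc4)nn23)cc1OC`, gives 35000 nM.
Compound 2, `COc1ccc(C(=O)/C=C/c2cc(-c3ccc(OC)c(OC)c3)n3nc(-c4ccccc4)cc3n2)cc1OC`, gives 32500 nM.
Compound 3, `COc1ccc(-c2cc(/C=C/C(=O)c3ccc(Cl)cc3)nc3cc(-c4ccccc4)nn23)cc1OC`, gives 44100 nM.

Compound 3 shows the highest number of the three, but its neighbours lie close: the step of a 1.3-fold higher number from compound 1 to compound 3 (0.10 log units; within the scatter) and the step of a 1.4-fold higher number from compound 2 to compound 3 (0.13 log units; within the scatter) are both within the scatter, as is a 1.1-fold lower number from compound 1 to compound 2 (0.03 log units; within the scatter), so none of the three compounds can be ranked against the others.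

Compound 4, `COc1ccc(/C=C/C(=O)c2cc(-c3ccc(OC)c(OC)c3)n3nc(-c4ccccc4)cc3n2)cc1`, has not yet been measured in this assay. It differs from compound 3 in one place: (2-(4-methoxyphenyl)ethenyl)carbonyl in place of 2-((4-chlorophenyl)carbonyl)ethenyl on an aromatic carbon. Two of the measured steps changed the aryl group on the carbonyl carbon, a 1.3-fold higher number from compound 1 to compound 3 (0.10 log units; within the scatter) and a 1.4-fold higher number from compound 2 to compound 3 (0.13 log units; within the scatter), and both stayed within the scatter. Compound 1 and compound 2 differ only by a methoxy group, and a 1.1-fold lower number from compound 1 to compound 2 (0.03 log units; within the scatter) was likewise within the scatter. For the measured compounds named here, the change from compound 3 to compound 4 exchanges the whole ethenyl-carbonyl chain together with its aryl group; no measured step covers exactly this exchange, but every measured variation in this part of the molecule left the number unchanged, so the expected step is none beyond the scatter: a 1.2-fold lower number from compound 3 to compound 4 (0.08 log units; within the scatter). Compound 4 is therefore estimated at 37000 nM, with a range from 18000 nM to 75000 nM.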

Compound 4, half-maximal inhibitory concentration: 50700 nM
The estimate for compound 4 lay 1.4-fold (0.14 log units) below the measured number, within the range that was stated.
By their numbers in this assay, from the lowest: compounds 2, 1, 3 and 4 (each within the scatter of the next).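

In this assay, for the compounds shown here, the earlier steps changed only the aryl group on the carbonyl carbon or removed a methoxy group, while the chain kept the same attachment to the shared core. The new change goes further: the carbonyl rather than the ethenyl now stands on the aromatic carbon, and 4-methoxyphenyl replaces 4-chlorophenyl at the far end, yet a 1.1-fold higher number from compound 3 to compound 4 (0.06 log units; within the scatter) still lies within the scatter, so even turning the chain round on this carbon, together with the exchange of its aryl group, gave no readable change among these compounds. As the two alterations arrive in one step, their separate contributions cannot be read, and nothing available offers a reason for this result.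

The compounds shown leave open whether any change on this aromatic carbon can move the number beyond the scatter, since all four carry a chain of carbonyl, ethenyl and aryl there. A simple amine or a carboxylic acid on that carbon in place of the whole chain would test this, as would a longer chain between the carbonyl and the aryl group.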